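This account rests on a few compounds, and the source may have more. Where it says the series, first, only, none or still open, it means among the compounds named here.

Measured compounds:
- compound 1 `Cc1cccc(-c2cccc(OC(=O)NC3CCCCC3)c2)c1`, 61.8 nM
- compound 2 `O=C(NC1CCCCC1)Oc1cccc(-c2cccc(F)c2)c1`, 96.6 nM
- compound 3 `O=C(NC1CCCCC1)Oc1cccc(-c2cccc(Cc3ccccc3)c2)c1`, 1860 nM

In an assay on cell membranes for binding affinity to Fatty-acid amide hydrolase 1 (Rattus norvegicus) (a lower number here means a stronger inhibitor, a higher number a weaker inhibitor), compound 3 stands highest of the three numbers; its nearest neighbour is compound 2, at a 19-fold higher number from compound 2 to compound 3 (1.28 log units; beyond the scatter), and compound 1 lies furthest, at a 30-fold higher number from compound 1 to compound 3 (1.48 log units; beyond the scatter). Both of these steps are beyond the scatter, and both end at the benzyl group of compound 3.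

Compound 4 `N#Cc1cccc(-c2cccc(OC(=O)NC3CCCCC3)c2)c1` has not yet been measured. It differs from compound 3 as follows: cyano in place of benzyl on an aromatic carbon. The two measured steps into compound 3 bear directly on this change, since both replace something other than benzyl by benzyl and both give a large rise; compound 4 runs the change in the opposite direction, and compound 1 and compound 2, which carry methyl or fluoro where compound 3 carries benzyl, sit within the scatter of each other. A large fall in this assay is therefore expected, of the order of a 21-fold lower number from compound 3 to compound 4 (1.32 log units; beyond the scatter), putting compound 4 near the values of compound 1 and compound 2. For compound 4 the estimate in this assay is 90 nM, with a range of 35 nM to 250 nM.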

Compound 4, half-maximal inhibitory concentration: 33.9 nM
Estimate against measurement, compound 4: 2.7-fold (0.42 log units) above, outside the stated range (below it).
By their numbers in this assay, from the lowest: compounds 4, 1 and 2 (each within the scatter of the next, the first and the last beyond it); then compound 3.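

In this assay, cyano at this aromatic carbon gives a 55-fold lower number from compound 3 to compound 4 (1.74 log units; beyond the scatter), so of the four groups now seen here, benzyl alone stands apart from the rest. Against fluoro, the change is modest, a 2.8-fold lower number from compound 2 to compound 4 (0.45 log units; beyond the scatter), and this is the first difference beyond the scatter among the groups other than benzyl. Against methyl, the step is a 1.8-fold lower number from compound 1 to compound 4 (0.26 log units; within the scatter), which lies within the scatter, so cyano and methyl cannot be told apart here and the separation holds only for cyano against fluoro.

Going by these compounds, it remains open whether an amine, a carboxylic acid or a methoxy group on this carbon would fall with methyl, fluoro and cyano or move toward benzyl. No measurement shown bears on why these groups differ.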